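The source may report more compounds than this note shows. Statements on the series, on what has been measured and on what is new or still open speak of the compounds shown alone.

Within the data shown here, compound 1 `C=CCn1c(=O)/c(=C\c2ccccc2Cl)[nH]c(=O)/c1=C\c1ccccc1OC` is the only member of this small set with a number: in a functional assay on U-937 cells (Homo sapiens) for cytotoxicity, read by CCK-8 assay, with a stated time of 72 h (on this read-out lower numbers stand for stronger inhibition and higher numbers for weaker inhibition), compound 1 gives 700 nM. Its companion compound 2 `C=CCn1c(=O)/c(=C\c2ccc(F)c(Br)c2)[nH]c(=O)/c1=C\c1ccccc1OC` is reported in this assay as "not active" (no number reported), without a number. Compound 3 `C=CCn1c(=O)/c(=C\c2cccc(C)c2)[nH]c(=O)/c1=C\c1ccccc1OC` carries the change (3-methylphenyl in place of 2-chlorophenyl on a double-bonded chain carbon bound to an aromatic carbon). Among the measured compounds shown here, no measured pair shows what this kind of exchange does, so the step from compound 1 to compound 3 is expected to be modest, leaning toward weaker inhibition, as a 2.1-fold higher number from compound 1 to compound 3 (0.33 log units; beyond the scatter). Compound 3 is therefore expected to give about 1500 nM, within 500 nM to 6000 nM.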

Compound 3, half-maximal inhibitory concentration: 5100 nM
Compound 3: middle estimate off by 3.4-fold (0.53 log units), on the low side; the range from low to high includes it.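

In this assay, among these compounds, the exchange of 2-chlorophenyl for 3-methylphenyl on a double-bonded chain carbon gives the first readable step at this position, a 7.3-fold higher number from compound 1 to compound 3 (0.86 log units; beyond the scatter). The position therefore responds to this exchange, yet compound 3 still keeps a number, whereas compound 2 is reported as not active. The data offer no measured explanation for this step. The compounds shown leave open whether the change follows from losing the chlorine or from the methyl group and its place on the ring. A 3-chlorophenyl or 2-methylphenyl group would separate these two readings.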